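The compounds below may be only part of what the source reports. "The series", "measured", "known", "first", "only" and "open" are said of these compounds alone.

Of the compounds shown here, two have been measured so far. Compound 1 `CCCCCn1ccc2cc(/C(C)=C/C(=O)Nc3ccccc3OCCCC(=O)O)ccc21` carries a butyl group on the aromatic nitrogen of the shared core and, in an assay on Prostate gland for inhibition of steroid 5-alpha-reductase (Rattus norvegicus) (on this read-out higher numbers stand for weaker inhibition and lower numbers for stronger inhibition), compound 1 gives 23 nM. Among the compounds with values here, compound 2 `C/C(=C\C(=O)Nc1ccccc1OCCCC(=O)O)c1ccc2c(ccn2Cc2cccc(C)c2)c1` carries a 3-methylbenzyl group at the same place and in this assay compound 2 gives 250 nM, the highest of the two numbers, with compound 1 as its only neighbour. Within the data shown here, the single step between them, an 11-fold higher number from compound 1 to compound 2 (1.04 log units; beyond the scatter), is the one comparison available.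

Compound 3 `C/C(=C\C(=O)Nc1ccccc1OCCCC(=O)O)c1ccc2c(ccn2C(CC(C)C)c2ccccc2)c1` differs from compound 2 by a single change, (3-methyl-1-phenylbutyl in place of 3-methylbenzyl on an aromatic nitrogen). The new group keeps a six-membered aromatic ring of carbon only and adds a branched saturated chain on the carbon bound to the aromatic nitrogen, so it combines features of the butyl of compound 1 and the 3-methylbenzyl of compound 2. Among the measured compounds shown here, the step from compound 1 to compound 2 gave the only direction here, and no measured pair tells how a further chain on that carbon is tolerated.

The number expected for compound 3 is 110 nM, with a range from 25 nM to 450 nM. This expectation amounts to a 2.3-fold lower number from compound 2 to compound 3 (0.36 log units; beyond the scatter), a modest move toward stronger inhibition with wide uncertainty.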

Compound 3, half-maximal inhibitory concentration: 6.3 nM
Compound 3: middle estimate off by 17-fold (1.24 log units), on the high side; the measured number lies below the stated range.
By their numbers in this assay, from the lowest: compound 3; then compound 1; then compound 2.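

In this assay the group on the aromatic nitrogen proves able to give much stronger inhibition when it carries both a ring and a branched chain: a 40-fold lower number from compound 2 to compound 3 (1.60 log units; beyond the scatter) accompanies 3-methyl-1-phenylbutyl in place of 3-methylbenzyl. Both groups hold one six-membered aromatic ring of carbon only, so the presence of that ring does not by itself set the number at this position, and the step from compound 1 to compound 2 cannot be read as a general penalty for such a ring. The saturated chain of compound 1 is also surpassed, with a 3.7-fold lower number from compound 1 to compound 3 (0.56 log units; beyond the scatter) as the step on the same position, while no information bearing on the reason for these steps is available.

The compounds shown do not separate the contribution of the branching from that of the added carbons, since a methyl group or a longer unbranched chain on the carbon bound to the aromatic nitrogen would be needed to do so. As far as these compounds go, it also remains open whether a hydroxyl group or an amine on that chain would keep the low number, and whether a substituent on the phenyl ring of compound 3 would behave as the 3-methylbenzyl of compound 2 does.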